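This account rests on a few compounds, and the source may have more. Where it says the series, first, only, none or still open, it means among the compounds named here.

Measured so far:
compound 1 `COc1ccc(/C=C/C(=O)c2ccc(N)c(-c3ccc(F)cc3)c2)cc1OC`, 6640 nM
compound 2 `O=C(/C=C/c1ccc(Cl)cc1)c1cccc(-c2cccc(F)c2)c1`, 16900 nM

In a functional assay on SW480 cells (Homo sapiens) for cytotoxicity, read by sulforhodamine B assay, with a stated time of 48 h (on this read-out lower numbers stand for stronger inhibition and higher numbers for weaker inhibition), compound 1 gives the lowest number of the two, and the nearest is compound 2 at a gap beyond the scatter. Compound 3 `COc1ccc(/C=C/C(=O)c2ccc(NC(C)=O)c(-c3ccc(F)cc3)c2)cc1OC` is not yet measured. It differs from compound 1 by acetyl in place of hydrogen on a nitrogen on an aromatic ring. Among the compounds with values here, no measured pair shows this change, so the size of the step is open. Within the data shown here, with no comparable step among the measured compounds, the expectation is a step no larger than the scatter, leaning weaker. Compound 3 is estimated at 8500 nM, with a range of 3000 nM to 25000 nM, an expected step of a 1.3-fold higher number from compound 1 to compound 3 (0.11 log units; within the scatter).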

Compound 3, half-maximal inhibitory concentration: 5350 nM
The estimate for compound 3 lay 1.6-fold (0.20 log units) above the measured number; the measured number falls inside the stated range.
By their numbers in this assay, from the lowest: compounds 3 and 1 (each within the scatter of the next); then compound 2.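

In this assay, the change from amino to acetamido, with acetyl in place of hydrogen on a nitrogen on an aromatic ring, gives a 1.2-fold lower number from compound 1 to compound 3 (0.09 log units; within the scatter). Within the data shown here, this nitrogen therefore carries the added acetyl with no step beyond the scatter, which is the first reading of any change at this place. Nothing available bears on the reason for this result.

From the compounds shown here alone, whether a longer acyl chain, a methanesulfonyl group or a simple methyl on this nitrogen would give a similar number remains open. This single pair also leaves open whether acetyl would give a similar step on a different core.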